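The source may report more compounds than this note shows. Statements on the series, on what has been measured and on what is new or still open speak of the compounds shown alone.

Measured so far: compound 1 `CN1CCc2nc(C#Cc3cccnc3)ccc2C1=O`; compound 2 `O=C1c2ccc(C#Cc3ccccc3Cl)nc2CCN1C1CCCC1`.

Among the measured compounds shown here, in a functional assay on HEK293 cells for positive allosteric modulation of metabotropic glutamate receptor 5 (Homo sapiens), read by FLIPR and calcium flux (a lower number here means that less compound is needed, a higher number that more compound is needed for the effect), compound 2 gives 393 nM, the only number in the set. In this assay compound 1 is reported as "not active" (no number reported), without a number. Compound 3 `O=C1c2ccc(C#Cc3cccnc3)nc2CCN1C1CCCC1` carries pyridin-3-yl in place of 2-chlorophenyl on a triple-bonded carbon. For the measured compounds named here, no step between two measured compounds ties this change to a number. Compound 1, which also carries pyridin-3-yl on a triple-bonded carbon, shows no activity, though it differs from compound 3 elsewhere too. The expected step from compound 2 to compound 3 in this assay is a 3.8-fold higher number from compound 2 to compound 3 (0.58 log units; beyond the scatter), a loss beyond the scatter. Compound 3 is therefore estimated at 1500 nM, within 400 nM to 6000 nM.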

Compound 3, half-maximal effective concentration: 748 nM
The estimate for compound 3 lay 2.0-fold (0.30 log units) above the measured number, within the range that was stated.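

In this assay, pyridin-3-yl in place of 2-chlorophenyl on a triple-bonded carbon gives a 1.9-fold higher number from compound 2 to compound 3 (0.28 log units; within the scatter), so this place accepts the ring nitrogen without a shift that can be told from the scatter. Pyridin-3-yl therefore goes with a measurable value in compound 3, which gives 748 nM, whereas compound 1, with the same group, gives "not active" (no number reported). No measurement shown explains this result. The compounds shown leave open how an unsubstituted phenyl or a pyridin-2-yl would read at this place. They also leave open whether an amine on the ring would be accepted.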